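From tert-butyl to methoxy on compound 2

The source may hold more compounds than are shown below. What is called first, only, known or untested is meant among the compounds shown, and "the series" means these compounds.

For the measured compounds named here, in a functional assay on HCT-116 cells (Homo sapiens) for antiproliferative activity, read by MTT assay, with a stated time of 72 h (on this read-out higher numbers stand for weaker inhibition and lower numbers for stronger inhibition), compound 2 `COc1ccc(/C=C2/CN(C)/C(=N/c3ccc(C(C)(C)C)cc3)S2)cc1` gives 25900 nM, the only number available in this small series. Compound 1 `C=C1CN/C(=N/c2ccccc2)S1` gives > 100000 nM, which is a limit of the assay and not a number. Compound 3 `C=C1CN(C)/C(=N/c2ccccc2)S1` gives > 100000 nM, again a limit. Most of the data therefore stand at the limit of > 100000 nM in this assay, at which 2 of the 3 values shown sit.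

The next compound to be read is compound 4 `COc1ccc(/C=C2/CN(C)/C(=N/c3ccc(OC)cc3)S2)cc1`, and the change leading to it is methoxy in place of tert-butyl on an aromatic carbon. The tert-butyl group leaves and methoxy enters at the same aromatic carbon, while the rest of the structure stays as it is.

Going by the values given here, only one measured step exists: a step that the two limits leave unreadable from compound 1 to compound 3. It concerns methyl in place of hydrogen on an amine nitrogen in a ring, not a group on an aromatic carbon, and it offers no size to carry over. Among the compounds with values here, no measured step covers the present change. With compound 2 at 25900 nM as the sole anchor, no shift beyond the scatter is expected in this assay, and the data favour no direction.

The expected change is a 1.2-fold higher number from compound 2 to compound 4 (0.06 log units; within the scatter), and it is an estimate with wide uncertainty. For compound 4 the estimated value is 30000 nM, with an expected range from 10000 nM to 90000 nM.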

Compound 4, half-maximal inhibitory concentration: 15900 nM
Beside the measured number, compound 4's estimate is 1.9-fold (0.28 log units) above it; the measured number falls inside the stated range.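

In this assay, for the compounds shown here, methoxy in place of tert-butyl on an aromatic carbon, para to a large group, gives a 1.6-fold lower number from compound 2 to compound 4 (0.21 log units; within the scatter), the first step that can be read as a size. The step lies within the scatter, so the two compounds cannot be ordered, and at this position the exchange of tert-butyl (4 heavy atoms, 0 hydrogen-bond acceptors) for methoxy (2 heavy atoms, 1 hydrogen-bond acceptor) leaves the read-out without a shift that can be told from repeat variation. The only earlier step, a change on the ring nitrogen, cannot be read, and it gave no such information about a group on this aromatic carbon, so this pair is the sole readable comparison so far and the data remain thin: the limit of > 100000 nM in this assay, at which 2 of the 4 values shown sit.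

Going by these compounds, whether any group at this aromatic carbon can move the number beyond the scatter remains open, for example an amine, a carboxylic acid or a longer chain. Compound 2 and compound 4 also share a second methoxy group, and no pair shown reads what that group contributes.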